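From Nitrophenyl to Methoxyphenyl on the Ring Amine

This account rests on a few compounds, and the source may have more. Where it says the series, first, only, none or still open, it means among the compounds named here.

Of the compounds shown here, three sharing one core have been tested in a functional assay (MiaPaCa cells, Homo sapiens) for inhibition, read by sulforhodamine B assay, with a stated time of 48 h; on this read-out lower numbers stand for stronger inhibition of growth and higher numbers for weaker inhibition of growth. Compound 1 `O=C(CCN1C(=O)CSc2ccccc21)N1CCN(c2ccccc2F)CC1` gives only a limit there, > 100000 nM. Where compound 1 carries a fluoro, compound 2 `COc1ccccc1N1CCN(C(=O)CCN2C(=O)CSc3ccccc32)CC1` carries a methoxy, and in this assay compound 2 gives 34900 nM. That change is an at least 2.8-fold lower number from compound 1 to compound 2 (0.45 log units; beyond the scatter). Compound 3 `O=C(CCN1C(=O)CSc2ccccc21)NCCCN1CCN(c2ccc([N+](=O)[O-])cc2)CC1`, with a longer linker and a 4-nitrophenyl group, also reaches only a limit, > 100000 nM. This is the limit of > 100000 nM in this assay, at which 2 of the 3 values shown sit, so compound 3 stands at the weak end of what has been seen, alongside compound 1. Compound 4 `COc1ccccc1N1CCN(CCCNC(=O)CCN2C(=O)CSc3ccccc32)CC1` differs from compound 3 by 2-methoxyphenyl in place of 4-nitrophenyl on an amine nitrogen in a ring. For the measured compounds named here, no measured step makes exactly this swap; the nearest is an at least 2.8-fold lower number from compound 1 to compound 2 (0.45 log units; beyond the scatter), in which the same 2-methoxyphenyl entered and the number moved from a limit to a measurable value. For compound 4 a step in the same direction is therefore expected, an at least 1.6-fold lower number from compound 3 to compound 4 (0.22 log units; that floor lies within the scatter). Compound 4 is thus estimated at 60000 nM in this assay, within 20000 nM to 200000 nM.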

Compound 4, concentration for 50% growth inhibition: 59200 nM
Beside the measured number, compound 4's estimate is 1.0-fold (0.01 log units) above it; the measured number falls inside the stated range.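

In this assay the swap on the longer linker gives an at least 1.6-fold lower number from compound 3 to compound 4 (0.22 log units; that floor lies within the scatter) and so the size of this change is known only as a floor. Compound 3 is a limit, not a number, and it shares that limit with compound 1: the limit of > 100000 nM in this assay, at which 2 of the 4 values shown sit. What is new is that the 2-methoxyphenyl on the amine nitrogen in the ring now gives a measurable number on both linkers, in compound 2 and in compound 4, whereas the fluoro and 4-nitrophenyl partners, compound 1 and compound 3, give only limits.

This swap changes the group and its place on the aromatic ring together, so the compounds shown do not separate the two. A 4-methoxyphenyl, a plain phenyl or a 2-chlorophenyl on that same nitrogen would tell them apart, and a longer chain would test the linker further.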